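Notes on the carbonyl substituent step from compound 3 to compound 4

This account rests on a few compounds, and the source may have more. Where it says the series, first, only, none or still open, it means among the compounds named here.

Measured in an assay on isolated protein for inhibition of aldehyde dehydrogenase 1A1 (Homo sapiens), read by spectrophotometry, tested at 10 uM; a lower number here means less inhibition, a higher number more inhibition at the concentration tested (going by the name of the read-out):
compound 1 `CCC(=O)N1CCN(Cc2nc3ccccc3n2Cc2cccc(C)c2)CC1` gives 85.1%
compound 2 `COc1ccc(C(=O)N2CCN(Cc3nc4ccccc4n3Cc3cccc(C)c3)CC2)cc1` gives 55.5%
compound 3 `Cc1cccc(Cn2c(CN3CCN(C(=O)C4CCCC4)CC3)nc3ccccc32)c1` gives 67.5%

Compound 3 is second highest of the three: the step of a number 17.6 percentage points lower from compound 1 to compound 3 (beyond the scatter) leaves it under compound 1, and the step of a number 12 percentage points higher from compound 2 to compound 3 (beyond the scatter) sets it above compound 2.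

Compound 4 `Cc1cccc(Cn2c(CN3CCN(C(=O)c4ccc(Br)cc4)CC3)nc3ccccc32)c1` is not yet measured; its change from compound 3 is 4-bromophenyl in place of cyclopentyl on a carbonyl carbon. Within the data shown here, the nearest precedent is the step of a number 12 percentage points higher from compound 2 to compound 3 (beyond the scatter), which swapped a six-membered aromatic ring for cyclopentyl on the same carbonyl carbon and was modest; the step of a number 29.6 percentage points lower from compound 1 to compound 2 (beyond the scatter) also shows an aromatic ring on that carbon below a small alkyl. A modest fall is therefore expected, a number 10.5 percentage points lower from compound 3 to compound 4 (beyond the scatter). Compound 4 is estimated at 57%, within 40% to 74%.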

Compound 4, a percentage reported as inhibition, at one concentration (the size of the read-out at that concentration, not a potency): 25.8%
The estimate for compound 4 lay 31.2 percentage points above the measured number, and the stated range ends above it.
By their numbers in this assay, from the lowest: compound 4; then compound 2; then compound 3; then compound 1.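

Moving to 4-bromophenyl on this carbonyl carbon gives a number 41.7 percentage points lower from compound 3 to compound 4 (beyond the scatter) and, from the ethyl amide, a number 59.3 percentage points lower from compound 1 to compound 4 (beyond the scatter), so the number with this aromatic ring is far lower than with either alkyl group. The ring substituent also matters, since bromo in place of methoxy on an aromatic carbon gives a number 29.7 percentage points lower from compound 2 to compound 4 (beyond the scatter) and the two aromatic amides are therefore not interchangeable. No measurement at hand accounts for these falls.

Going by these compounds, it remains open where unsubstituted phenyl would fall relative to the methoxy and bromo compounds. Also open, on these data alone, is whether a longer chain, such as butyl, would keep the level of the ethyl amide.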